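The compounds below may be only part of what the source reports. "The series", "measured", "known", "first", "only" and "open" are said of these compounds alone.

Within the data shown here, in an ADME assay on microsomes from liver (Homo sapiens) for metabolic stability (on this read-out lower numbers stand for slow clearance and higher numbers for fast clearance), compound 1 `Cc1csc2nc(Cn3cnc4ccccc43)cc(=O)n12` gives 8 mL.min-1.g-1, the lowest number of the three compounds measured so far. Compound 2 `Cc1cccn2c(=O)cc(Cn3cnc4ccccc43)nc12` gives 17.8 mL.min-1.g-1 and compound 3 `COc1cccc(NS(=O)(=O)c2cc3c(cc2Cl)NC(=O)CO3)c1` gives 22.4 mL.min-1.g-1, both higher than compound 1 by more than the usual scatter. Compound 4 `O=c1cc(Cn2cnc3ccccc32)nc2sccn12` has not yet been measured. It differs from compound 1 by hydrogen in place of methyl on an aromatic carbon. Among the measured compounds shown here, no measured pair shows the effect of a single change of this kind, so no step beyond the scatter is expected in this assay. The expected change is a 1.1-fold lower number from compound 1 to compound 4 (0.06 log units; within the scatter). Compound 4 is estimated at 7 mL.min-1.g-1, with an expected range of 3.5 mL.min-1.g-1 to 15 mL.min-1.g-1.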

Compound 4, intrinsic clearance in microsomes in the Homo sapiens assay: 8 mL.min-1.g-1
Compound 4: middle estimate off by 1.1-fold (0.06 log units), on the low side; the measured number falls inside the stated range.
By their numbers in the Homo sapiens assay, from the lowest: compounds 1 and 4 (each within the scatter of the next); then compounds 2 and 3 (each within the scatter of the next).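

Among these compounds, in the Homo sapiens assay, hydrogen in place of methyl on this aromatic carbon gives no change at the digits printed from compound 1 to compound 4 (within the scatter), the first reading of a single change at this position. The methyl can therefore go without any visible cost on this read-out. In a physicochemical assay for solubility, measured as kinetic solubility, at pH 7.4 (on this read-out higher numbers stand for higher solubility and lower numbers for lower solubility), compound 1 gives 117000 nM and compound 4 gives 569000 nM on this read-out. In the physicochemical assay, the same change does separate the two compounds, and compound 4 is the more soluble of the pair: the measured solubility of compound 1, 117000 nM, and of compound 4, 569000 nM, a 4.9-fold higher number (0.69 log units; beyond the scatter)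

From the compounds shown here alone, whether an amine or a longer chain on this aromatic carbon would leave the number in the Homo sapiens assay unchanged remains open. So does how such a group would shift the number in the physicochemical assay.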